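Replacing the aryl group on a shared core

The source may hold more compounds than are shown below. What is called first, only, known or untested is meant among the compounds shown, and "the series" means these compounds.

Three measured compounds share one core and differ only in the group attached to one aromatic carbon of that core. Compound 1 `CCOC(=O)c1cnc(-c2cnc3ccccc3c2)nc1NN1C(=O)C=C(C)C1=O` carries quinolin-3-yl, compound 2 `CCOC(=O)c1cnc(-n2nc(C)cc2C)nc1NN1C(=O)C=C(C)C1=O` carries 3,5-dimethyl-1H-pyrazol-1-yl, and compound 3 `CCOC(=O)c1cnc(-c2ccc(C(F)(F)F)cc2)nc1NN1C(=O)C=C(C)C1=O` carries 4-(trifluoromethyl)phenyl. In a functional assay on Jurkat cells for inhibition of nuclear factor NF-kappa-B complex (Homo sapiens) (a higher number here means a weaker inhibitor, a lower number a stronger inhibitor), compound 1 gives 6000 nM, compound 2 gives 10000 nM, and compound 3 gives 400 nM. Compound 3 thus stands at the lowest number of the three: the step of a 15-fold lower number from compound 1 to compound 3 (1.18 log units; beyond the scatter) and the step of a 25-fold lower number from compound 2 to compound 3 (1.40 log units; beyond the scatter) are both large, whereas the step of a 1.7-fold higher number from compound 1 to compound 2 (0.22 log units; within the scatter) stays within the scatter.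

Compound 4 `CCOC(=O)c1cnc(C(=O)c2ccco2)nc1NN1C(=O)C=C(C)C1=O` has not yet been measured. It differs from compound 3 in a single place: (furan-2-yl)carbonyl in place of 4-(trifluoromethyl)phenyl on an aromatic carbon. The two large measured steps show that exchanging the group at this position moves the number strongly, and both exchanges away from 4-(trifluoromethyl)phenyl gave much higher numbers. Among the compounds with values here, no measured compound carries a carbonyl-linked group here, so the size of the expected step is uncertain, but a clear rise is expected, a 7.5-fold higher number from compound 3 to compound 4 (0.88 log units; beyond the scatter). Compound 4 is therefore estimated to give 3000 nM in this assay, within a range from 800 nM to 10000 nM.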

Compound 4, half-maximal inhibitory concentration: 700 nM
Beside the measured number, compound 4's estimate is 4.3-fold (0.63 log units) above it; the measured number lies below the stated range.
By their numbers in this assay, from the lowest: compounds 3 and 4 (each within the scatter of the next); then compounds 1 and 2 (each within the scatter of the next).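

In this assay, within the data shown here, only 4-(trifluoromethyl)phenyl had so far given a low number at this position, yet (furan-2-yl)carbonyl, with its five-membered aromatic ring and a carbonyl link, reads level with it: the exchange gives a 1.8-fold higher number from compound 3 to compound 4 (0.24 log units; within the scatter) and so does not separate the two groups. Among these compounds, the new group also stands apart from the other two, with a 14-fold lower number from compound 2 to compound 4 (1.15 log units; beyond the scatter) and an 8.6-fold lower number from compound 1 to compound 4 (0.93 log units; beyond the scatter) showing that a six-membered carbon ring bearing trifluoromethyl is not the only group here that reaches the low range. Nothing available gives a reason why two such different groups read alike.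

Among the compounds shown here, it remains open whether the carbonyl link or the furan ring matters more, since no compound here has one without the other; a benzoyl group, or a furan-2-yl group joined directly to the aromatic carbon, would pull the two apart. Also open, from the compounds shown here alone, is how a small group such as an amine or a plain methyl would behave on this same carbon.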